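Enamine curcuminoid series: chain length at the amine nitrogen

This account rests on a few compounds, and the source may have more. Where it says the series, first, only, none or still open, it means among the compounds named here.

Measured compounds:
- compound 1 `CCCNC(=C\C(=O)/C=C/c1ccc(O)c(OC)c1)/C=C/c1ccc(O)c(OC)c1`, 88%
- compound 2 `C=CCNC(=C\C(=O)/C=C/c1ccc(O)c(OC)c1)/C=C/c1ccc(O)c(OC)c1`, 76%
- compound 3 `CC(=O)Oc1ccc(/C=C/C(=O)/C=C(/C=C/c2ccc(OC(C)=O)cc2)NCC(C)C)cc1`, 85%

In a functional assay on Caco-2 cells (Homo sapiens), read by fluorescence, tested at 10 uM (on this read-out lower numbers stand for a stronger effect and higher numbers for a weaker effect at the one concentration tested), compound 2 gives the lowest of the three numbers. Its nearest neighbour is compound 3, which lies within the scatter of it, while compound 1 lies beyond the scatter above it.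

The next compound, compound 4 `CCCCNC(=C\C(=O)/C=C/c1ccc(O)c(OC)c1)/C=C/c1ccc(O)c(OC)c1`, differs from compound 2 in a single place: propyl in place of vinyl on a saturated chain carbon bound to an amine nitrogen.

Among the measured compounds shown here, only one measured step bears on this change. The step of a number 12 percentage points lower from compound 1 to compound 2 (beyond the scatter) introduced the vinyl group in place of ethyl on the saturated chain carbon bound to the amine nitrogen and lowered the number modestly. The step to compound 4 removes that vinyl group again and lengthens the saturated chain, so the expectation is that the number returns roughly to where compound 1 stands, a step upward from compound 2 of about a number 10 percentage points higher from compound 2 to compound 4 (within the scatter). For the measured compounds named here, the extra chain length has no measured precedent here, so the range is kept wide.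

For compound 4 in this assay the estimated value is 86%, with a range from 74% to 97%.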

Compound 4, a percentage reported as activity, at one concentration (the size of the read-out at that concentration, not a potency): 83%
The estimate for compound 4 lay 3 percentage points above the measured number; measured number inside the range.
By their numbers in this assay, from the lowest: compounds 2, 4, 3 and 1 (each within the scatter of the next, the first and the last beyond it).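

In this assay, allylamino to butylamino gives a number 7 percentage points higher from compound 2 to compound 4 (within the scatter), and adding one carbon to the saturated chain gives a number 5 percentage points lower from compound 1 to compound 4 (within the scatter). Compound 4 therefore lies within the scatter of both compound 1 and compound 2, so butyl does not side clearly with either propyl or allyl, and the step of a number 12 percentage points lower from compound 1 to compound 2 (beyond the scatter) does not show a clean split between saturated and unsaturated chains at this position. Nothing at hand explains these numbers.

As far as these compounds go, whether a longer chain such as hexyl would move the number beyond the scatter remains open. So does whether a chain ending in a hydroxyl group or a carboxylic acid would do so, and whether the allyl step holds on a different core.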